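This account rests on a few compounds, and the source may have more. Where it says the series, first, only, none or still open, it means among the compounds named here.

In a functional assay on HepG2 cells (Homo sapiens) for antiproliferative activity, read by MTT assay, with a stated time of 48 h (a higher number here means a weaker inhibitor, a lower number a stronger inhibitor), compound 1 `COc1ccc(-c2c(Nc3ccc(C)c(O)c3)c3ccccc3oc2=O)cc1` gives 10200 nM as the first reference point for the series. Compound 2 `COc1ccc(-c2c(Nc3ccc(C)c(O)c3)c3ccc(OC)cc3oc2=O)cc1` gives 22500 nM and holds the higher of the two numbers, which makes it the weaker inhibitor of this pair. For the measured compounds named here, the only measured step is a 2.2-fold higher number from compound 1 to compound 2 (0.34 log units; beyond the scatter) and it comes from a methoxy in place of hydrogen on an aromatic carbon.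

The next change leads to compound 3 `COc1ccc(-c2c(Nc3ccc(NC(C)=O)cc3)c3ccc(OC)cc3oc2=O)cc1` and is described by 4-acetamidophenyl in place of 3-hydroxy-4-methylphenyl on a nitrogen on an aromatic ring with the core of compound 2 left as it is. In words, this is 4-acetamidophenyl in place of 3-hydroxy-4-methylphenyl on a nitrogen on an aromatic ring. Going by the values given here, no measured pair varies this group, so the data give no direct guide to the direction of the change. The step of a 2.2-fold higher number from compound 1 to compound 2 (0.34 log units; beyond the scatter) offers only a rough size for a single change in this small series. A modest move at most is therefore expected, possibly none beyond the scatter. The estimated step is a 1.3-fold lower number from compound 2 to compound 3 (0.10 log units; within the scatter) in this assay and its direction is not firmly supported. The estimate for compound 3 is 18000 nM with an expected range from 6000 nM to 50000 nM in this working view.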

Compound 3, half-maximal inhibitory concentration: > 100000 nM
Compound 3: no number, only a limit (the forecaster's own chance of this, stated with the estimate: 10%); middle value at least 5.5-fold (0.74 log units) away from the limit.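

In this assay, the group on the nitrogen on an aromatic ring proves to be a sensitive place in the series: 4-acetamidophenyl in place of 3-hydroxy-4-methylphenyl gives an at least 4.4-fold higher number from compound 2 to compound 3 (0.64 log units; beyond the scatter), a larger printed step than the methoxy change on the core, a 2.2-fold higher number from compound 1 to compound 2 (0.34 log units; beyond the scatter). The two groups have equal counts of hydrogen-bond donors and acceptors and each holds one six-membered aromatic ring of carbon only, so these counts alone do not track the loss seen here. The reading for compound 3 is a limit and not a number, and the step gives only a lower bound on the true size of the change: the limit of > 100000 nM in this assay, at which 1 of the 3 values shown sits.

For the compounds shown here, the single exchange leaves open whether the loss follows from removing the hydroxy and methyl groups or from adding the acetamido group, and whether it would also appear on the core of compound 1 without the added methoxy. An unsubstituted phenyl or an aminophenyl on the same nitrogen would help separate these possibilities, as neither group is among the compounds shown.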